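The compounds below may be only part of what the source reports. "The series", "measured", "known", "first", "only" and "open" are said of these compounds alone.

Measured compounds:
- compound 1 `O=C(/C=C/c1ccccc1)NS(=O)(=O)c1ccc(Br)cc1`: 3.9 ug/mL
- compound 2 `COc1ccc(/C=C/C(=O)NS(=O)(=O)c2ccc(C)cc2)cc1`: 12.2 ug/mL

In a functional assay on B16-F10 cells (Mus musculus) for antiproliferative activity, read by ELISA and MTT assay, with a stated time of 48 h (on this read-out higher numbers stand for weaker inhibition and lower numbers for stronger inhibition), compound 2 gives the highest of the two numbers; its nearest neighbour, compound 1, gives a number beyond the scatter below it. Compound 3 `COc1ccc(/C=C/C(=O)NS(=O)(=O)c2ccc(Br)cc2)cc1` is not yet measured. It differs from compound 2 in one place: bromo in place of methyl on an aromatic carbon. Going by the values given here, no step between measured compounds isolates this single change, since compound 1 and compound 2 differ in two places, so the size of the step cannot be read from the data directly. Compound 3 is expected to reach a somewhat lower number than compound 2, with a step of a 1.6-fold lower number from compound 2 to compound 3 (0.21 log units; within the scatter), modest and possibly no larger than the scatter. Accordingly compound 3 is estimated at 7.5 ug/mL in this assay, with a plausible range from 3 ug/mL to 16 ug/mL.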

Compound 3, half-maximal inhibitory concentration: 5.8 ug/mL
For compound 3 the middle estimate is 1.3-fold (0.11 log units) above the measured one; the range from low to high includes it.
By their numbers in this assay, from the lowest: compounds 1 and 3 (each within the scatter of the next); then compound 2.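

In this assay, the change from 4-methylphenyl to 4-bromophenyl can now be sized on its own: with the methoxy group kept, bromo in place of methyl gives a 2.1-fold lower number from compound 2 to compound 3 (0.32 log units; beyond the scatter), a modest step but one that clears the usual scatter. With bromo kept, methoxy in place of hydrogen gives a 1.5-fold higher number from compound 1 to compound 3 (0.17 log units; within the scatter), so this second change shows no clear effect on the read-out. The data shown offer no measurement that would explain either step.

Going by these compounds, it remains open how chloro, an amine or a carboxylic acid on that same aromatic carbon would compare with bromo and methyl. On these data alone, it is also open whether the step from methyl to bromo would keep its size on a core without the methoxy group.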